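One halogenated ring for another on compound 3

A few compounds are considered here, and "the series" means these few. Any claim that something is new, unique, unknown or untested is made for them only; others in the source may bear on it.

Compound 1 `O=C1C(NC2CCCC2)=CC(=O)c2c1nc1n2[C@H]2OC[C@@H](O)[C@H]2OC1` gives > 16000 nM, which is a limit of the assay rather than a number.
Compound 2 `O=C1C(N2CCCC2)=CC(=O)c2c1nc1n2[C@H]2OC[C@@H](O)[C@H]2OC1` gives > 16000 nM, again only a limit.
Compound 3 `O=C1C=C(Nc2ccc(Br)cc2)C(=O)c2c1nc1n2[C@H]2OC[C@@H](O)[C@H]2OC1` gives 2850 nM.

These three compounds share one core and were tested in a functional assay on ECa-109 cells for inhibition, with ECa-109 cell line (Homo sapiens) as the target, read by sulforhodamine B assay; a lower number here means a stronger inhibitor, a higher number a weaker inhibitor. Compound 3 is the only one of the three with an actual number; the other two sit at the limit of > 16000 nM in this assay, at which 2 of the 3 values shown sit. Going by the values given here, the single step between measured compounds, a step that the two limits leave unreadable from compound 1 to compound 2, concerns the substituent on the double-bonded ring carbon, and because both of its ends are limits it cannot be read.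

Compound 4 `O=C1C=C(Nc2cccc(Cl)c2)C(=O)c2c1nc1n2[C@H]2OC[C@@H](O)[C@H]2OC1` has not yet been measured in this assay. It differs from compound 3 by 3-chlorophenyl in place of 4-bromophenyl on an amine nitrogen. Among the compounds with values here, no measured step touches this kind of change, so the expectation rests only on compound 3 itself. The change is expected to move the value by no more than the usual scatter, so the estimated step of a 1.1-fold higher number from compound 3 to compound 4 (0.02 log units; within the scatter) is small. Compound 4 is therefore expected to give about 3000 nM, between 1000 nM and 9000 nM.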

Compound 4, half-maximal inhibitory concentration: 4690 nM
Compound 4: middle estimate off by 1.6-fold (0.19 log units), on the low side, within the range that was stated.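

In this assay, going by these compounds alone, the change to the group on the amine nitrogen gives the first step that can be read, a 1.6-fold higher number from compound 3 to compound 4 (0.22 log units; within the scatter), and it lies within the scatter. At this position, therefore, 4-bromophenyl and 3-chlorophenyl cannot be told apart, even though the swap alters both the halogen and where it sits on the ring. Compound 4 also gives a real number, as compound 3 does, whereas the two other compounds stop at a limit of the assay: the limit of > 16000 nM in this assay, at which 2 of the 4 values shown sit.

Since both features change together and the values stay within the scatter, the compounds shown cannot say whether either feature matters alone. Also open, from the compounds shown here alone, is how a plain phenyl ring, or a phenyl ring carrying a methoxy group or a carboxylic acid, would behave on this amine nitrogen.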